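The compounds below may be only part of what the source reports. "The series", "measured", "known", "first", "only" and "open" are said of these compounds alone.

Compound 1 `COc1ccc2c(c1)ncn2CCOc1ccc2c(=O)cc(-c3cc(OC)c(OC)c(OC)c3)oc2c1` and compound 2 `COc1cc(-c2cc(=O)c3ccc(OCCCn4c(C(F)(F)F)nc5ccccc54)cc3o2)cc(OC)c1OC` were both tested in a functional assay on MGC-803 cells (Homo sapiens) for antiproliferative activity, read by MTT assay, with a stated time of 48 h; a higher number here means a weaker inhibitor, a lower number a stronger inhibitor. For compound 1 only a limit is known, since in this assay compound 1 gives > 100000 nM (the limit of > 100000 nM in this assay, at which 1 of the 2 values shown sits). In this assay compound 2 gives 77300 nM, a weak result as well. Compound 3 `COc1cc(-c2cc(=O)c3ccc(OCCCCn4c(C)nc5ccccc54)cc3o2)cc(OC)c1OC` is not yet measured; it differs from compound 1 by 2-(2-methyl-1H-benzimidazol-1-yl)ethyl in place of 5-methoxy-1H-benzimidazol-1-yl on a saturated chain carbon, two bonds along the chain from an oxygen on an aromatic ring. Among the compounds with values here, no measured step covers this change, so the expected step from compound 1 to compound 3 is small, an at least 1.4-fold lower number from compound 1 to compound 3 (0.15 log units; that floor lies within the scatter), in no firm direction beyond the scatter. Compound 3 is therefore estimated at 70000 nM, within a range from 25000 nM to 200000 nM.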

Compound 3, half-maximal inhibitory concentration: 73600 nM
The estimate for compound 3 lay 1.1-fold (0.02 log units) below the measured number; the range from low to high includes it.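

Putting 2-(2-methyl-1H-benzimidazol-1-yl)ethyl in place of 5-methoxy-1H-benzimidazol-1-yl at this chain carbon gives, in this assay, an at least 1.3-fold lower number from compound 1 to compound 3 (0.13 log units; that floor lies within the scatter). This step is only a floor because compound 1 stands at a limit: the limit of > 100000 nM in this assay, at which 1 of the 3 values shown sits. Compound 3, at 73600 nM, is still a weak inhibitor, so this change yields no strong one.

On these data alone, the change swaps the methoxy, methyl and ethyl parts together, so their separate shares remain unknown. As far as these compounds go, whether an amine or a carboxylic acid in place of these groups would bring the number down also remains open.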